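The source may hold more compounds than are shown below. What is called first, only, known or untested is meant among the compounds shown, and "the series" means these compounds.

Measured so far in a functional assay on PANC-1 cells (Homo sapiens) for inhibition, read by MTT assay, with a stated time of 24 h; on this read-out higher numbers stand for weaker inhibition and lower numbers for stronger inhibition:
- compound 1 `CC1(C)[C@H]2CC[C@]1(C)N(Cc1cn(-c3cccc(F)c3)nn1)C(=O)C2` gives 220 nM
- compound 2 `CC1(C)[C@H]2CC[C@]1(C)N(Cc1cn(-c3cccc(C#N)c3)nn1)C(=O)C2` gives 260 nM
- compound 3 `CC1(C)[C@H]2CC[C@]1(C)N(Cc1cn(-c3ccc(F)cc3)nn1)C(=O)C2` gives 110 nM

Compound 3 holds the lowest number of the three, but its gap to compound 1 is within the scatter; only the gap to compound 2 is beyond it. Compound 4 `COc1ccccc1-n1cc(CN2C(=O)C[C@@H]3CC[C@@]2(C)C3(C)C)nn1` differs from compound 3 as follows: 2-methoxyphenyl in place of 4-fluorophenyl on an aromatic nitrogen. For the measured compounds named here, the steps that bear on this are the earlier changes on the same phenyl group, a 2.0-fold lower number from compound 1 to compound 3 (0.30 log units; within the scatter) and a 2.4-fold lower number from compound 2 to compound 3 (0.37 log units; beyond the scatter), both small. Nothing measured yet carries a methoxy group or a group at this position of the phenyl, so direction is uncertain; a small step is expected, and since compound 3 sits lowest, the number of compound 4 is expected to come out a little higher, as a 1.6-fold higher number from compound 3 to compound 4 (0.21 log units; within the scatter). In this assay compound 4 is thus estimated at 180 nM, within a range of 80 nM to 450 nM.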

Compound 4, half-maximal inhibitory concentration: 120 nM
The estimate for compound 4 lay 1.5-fold (0.18 log units) above the measured number; the range from low to high includes it.
By their numbers in this assay, from the lowest: compounds 3, 4, 1 and 2 (each within the scatter of the next, the first and the last beyond it).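

In this assay, 2-methoxyphenyl on the aromatic nitrogen keeps the number within the scatter of both fluorophenyl compounds, with a 1.1-fold higher number from compound 3 to compound 4 (0.04 log units; within the scatter) and a 1.8-fold lower number from compound 1 to compound 4 (0.26 log units; within the scatter), so a phenyl group with its substituent in this new place and carrying oxygen gives no measurable loss against them. Only a 2.2-fold lower number from compound 2 to compound 4 (0.34 log units; beyond the scatter) lies beyond the scatter, and it is modest. Nothing at hand gives a reason for these numbers.

Open, on these data alone, is whether the methoxy group or its place on the phenyl sets the number, which 2-fluorophenyl and 4-methoxyphenyl would separate. Also open, as far as these compounds go, is how an amine, a carboxylic acid or a longer chain on the phenyl would read.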